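The compounds below may be only part of what the source reports. "The series", "measured", "known", "first", "only" and "open" are said of these compounds alone.

Working notes, TRPV1 series.

Compound 3 `CC(C(=O)NCc1ccc(C(C)(C)C)cc1OC1CCCC1)c1ccc(NS(C)(=O)=O)c(F)c1` gives 1.8 nM in an assay on cells for antagonist activity at transient receptor potential cation channel subfamily V member 1 (Homo sapiens), read by FLIPR and calcium flux, with a stated time of 6 min (on this read-out higher numbers stand for weaker inhibition and lower numbers for stronger inhibition), the second highest number of the three measured. Compound 1 `CC1CCN(c2cc(C(C)(C)C)ccc2CNC(=O)C(C)c2ccc(NS(C)(=O)=O)c(F)c2)CC1` gives 0.7 nM in this assay, and compound 2 `CCCOc1cc(C(C)(C)C)ccc1CNC(=O)C(C)c1ccc(NS(C)(=O)=O)c(F)c1` gives 4.4 nM. The steps among them are all of modest size: a 2.6-fold higher number from compound 1 to compound 3 (0.41 log units; beyond the scatter), a 6.3-fold higher number from compound 1 to compound 2 (0.80 log units; beyond the scatter), and a 2.4-fold lower number from compound 2 to compound 3 (0.39 log units; beyond the scatter).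

Compound 4 `CC(C(=O)NCc1ccc(C(C)(C)C)cc1C1CCCCC1)c1ccc(NS(C)(=O)=O)c(F)c1` differs from compound 3 in one place: cyclohexyl in place of cyclopentyloxy on an aromatic carbon. Going by the values given here, only one measured step touches this position in a comparable way, namely the exchange of a chain for a ring on the oxygen going from compound 2 to compound 3, which was modest. Among the compounds with values here, no measured step removes the oxygen itself while keeping a carbon ring, so the direction of the present change is not covered by the measured pairs. Given that every step at this position so far stayed within a modest range, the expected step is a 1.7-fold higher number from compound 3 to compound 4 (0.22 log units; within the scatter), small and of uncertain direction. Compound 4 is therefore expected to give about 3 nM in this assay, with a range from 0.8 nM to 12 nM.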

Compound 4, inhibition constant: 9.8 nM
Compound 4: middle estimate off by 3.3-fold (0.51 log units), on the low side, and the stated range covers the measured number.
By their numbers in this assay, from the lowest: compound 1; then compound 3; then compound 2; then compound 4.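

At this aromatic carbon, the ring joined through oxygen does not carry over to a directly attached carbon ring: in this assay, cyclohexyl in place of cyclopentyloxy gives (a 5.4-fold higher number from compound 3 to compound 4 (0.74 log units; beyond the scatter)), a clear upward step where the earlier change on the oxygen had gone down. Cyclohexyl also falls behind the open-chain propoxy (a 2.2-fold higher number from compound 2 to compound 4 (0.35 log units; beyond the scatter)) and behind 4-methylpiperidin-1-yl (a 14-fold higher number from compound 1 to compound 4 (1.15 log units; beyond the scatter)), the only large step in the set, which leaves compound 4 the weakest of the four. No measurement at hand bears on the reason for these steps.

The loss of the oxygen and the change from a five-membered to a six-membered ring arrive together here, and the compounds shown do not separate them. A cyclopentyl or cyclohexyloxy group at this carbon would do so, and a morpholin-4-yl group would test whether the advantage of 4-methylpiperidin-1-yl extends to other ring amines.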